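Cyclopentyl Amide Step Repeated on a Brominated Core

The source may report more compounds than this note shows. Statements on the series, on what has been measured and on what is new or still open speak of the compounds shown alone.

Compound 1 `COc1cccc2cc(C(=O)NC3CCCC3)c(=N)oc12` and compound 2 `CCC(CO)NC(=O)c1cc2cccc(OC)c2oc1=N` share one core; compound 3 `CCC(CO)NC(=O)c1cc2cc(Br)ccc2oc1=N` and compound 4 `N=c1oc2ccc(Br)cc2cc1C(=O)NC1CCCC1` share another, and the difference between the two cores is not broken down here. In an assay on HeLa cells for displacement of a labelled ligand from adenosine receptor A3 (Homo sapiens), read by scintillation counting, with a stated time of 180 min, tested at 10 uM (a higher number here means more inhibition at the concentration tested (going by the name of the read-out), a lower number less inhibition), compound 2 gives 6%, while compound 1 gives 20%; the change cyclopentyl in place of 1-(hydroxymethyl)propyl on an amide-type nitrogen produced a number 14 percentage points higher from compound 2 to compound 1 (beyond the scatter). Compound 3 gives 24% in this assay. The same change, (cyclopentyl in place of 1-(hydroxymethyl)propyl on an amide-type nitrogen), leads to compound 4, which awaits measurement. Because the earlier step of a number 14 percentage points higher from compound 2 to compound 1 (beyond the scatter) went upward beyond the scatter, a step of similar size is expected here, a number 14 percentage points higher from compound 3 to compound 4 (beyond the scatter). Compound 4 is therefore estimated at 38%, between 24% and 52%. This estimate rests on compound 3 with 24% and on that one earlier step, so it carries real uncertainty.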

Compound 4, a percentage reported as inhibition, at one concentration (the size of the read-out at that concentration, not a potency): 0%
Compound 4: the middle estimate sits 38 percentage points above what was measured; measured number outside the range, below it.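

In this assay, the same exchange of 1-(hydroxymethyl)propyl for cyclopentyl on the amide-type nitrogen, applied to the second core, gave a number 24 percentage points lower from compound 3 to compound 4 (beyond the scatter), so the earlier upward step did not carry over. In these two pairs, the outcome of the change therefore depends on the core it is made on, and the two steps differ in direction: the same change on two cores in this assay, a number 14 percentage points higher (beyond the scatter) from compound 2 to compound 1 and a number 24 percentage points lower (beyond the scatter) from compound 3 to compound 4, 38 percentage points apart, beyond the scatter of two such steps This does not show which feature of the two cores is responsible, nor how the change would behave on any further core.

The compounds shown leave open how other groups on this nitrogen would behave on either core. A cyclohexyl ring, a plain butyl chain or a chain ending in an amine might follow either step or neither.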